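Chlorine Shift on the Amide-Bound Ring: Expected Lipophilicity

The source may report more compounds than this note shows. Statements on the series, on what has been measured and on what is new or still open speak of the compounds shown alone.

Three compounds have been measured in a physicochemical assay for lipophilicity; a higher number here means a more lipophilic compound, a lower number a more polar compound:
compound 1 `CCCCCCCNC(=O)Oc1ccc(Cl)cc1C(=O)Nc1cccc(Cl)c1` gives 5.94;
compound 2 `CCCCCCCCCNC(=O)Oc1ccc(Cl)cc1C(=O)Nc1cccc(Cl)c1` gives 6.78;
compound 3 `CCCCCCCCCCNC(=O)Oc1ccc(Cl)cc1C(=O)Nc1cccc(Cl)c1` gives 7.19.

Compound 2 stands second highest of the three in this assay: a number 0.41 log units higher from compound 2 to compound 3 (beyond the scatter), while a number 0.84 log units higher from compound 1 to compound 2 (beyond the scatter).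

Compound 4 `CCCCCCCCCNC(=O)Oc1ccc(Cl)cc1C(=O)Nc1ccc(Cl)cc1` differs from compound 2 by 4-chlorophenyl in place of 3-chlorophenyl on an amide-type nitrogen. Going by the values given here, every measured step, namely a number 0.84 log units higher from compound 1 to compound 2 (beyond the scatter), a number 1.25 log units higher from compound 1 to compound 3 (beyond the scatter) and a number 0.41 log units higher from compound 2 to compound 3 (beyond the scatter), lengthens the saturated chain; none alters the ring on the amide-type nitrogen, so no measured step bears directly on this change. The expected step in this assay is accordingly none beyond the scatter, a number 0.07 log units higher from compound 2 to compound 4 (within the scatter). Compound 4 is estimated at 6.85, with a range from 6.4 to 7.3.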

Compound 4, partition coefficient: 6.78
Compound 4: middle estimate off by 0.07 log units, on the high side, within the range that was stated.
By their numbers in this assay, from the lowest: compound 1; then compounds 2 and 4 (each within the scatter of the next); then compound 3.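

In this assay the change to 4-chlorophenyl in place of 3-chlorophenyl on an amide-type nitrogen gives no change at the digits printed from compound 2 to compound 4 (within the scatter) and is the only step shown at this position, since the earlier compounds differ only in the saturated chain. With the chain of compound 2, this ring change therefore leaves the reading within the scatter. Nothing available explains this result.

Going by these compounds, whether the same holds with the shorter chain of compound 1 or the longer chain of compound 3 stays open. So does the reading in this assay with an amine or a carboxylic acid on this ring.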